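Swapping Acetyl for Dimethylamino on a Cytotoxic Pyrazole Series

A few compounds are considered here, and "the series" means these few. Any claim that something is new, unique, unknown or untested is made for them only; others in the source may bear on it.

Measured compounds:
- Compound 1 `COc1cc(C)cc(-c2c(-c3ccnc(-c4ccc(C(C)=O)cc4)c3)cnn2CC#N)c1`: 81%
- Compound 2 `COc1cc(C)cc(-c2nn(CC#N)cc2-c2ccc(-c3cccc(C(C)=O)c3)nc2)c1`: 84%
- Compound 3 `Cc1cc(O)cc(-c2nn(CC#N)cc2-c2ccnc(-c3ccc(Oc4ccccc4)cc3)c2)c1`: 79%

All three compounds were tested in a functional assay on MOLT-4 cells (Homo sapiens) for cytotoxicity, read by sulforhodamine B assay, with a stated time of 48 h, tested at 100 nM; on this read-out lower numbers stand for a stronger effect and higher numbers for a weaker effect at the one concentration tested. In this assay compound 1 gives 81%, compound 2 gives 84% and compound 3 gives 79%. The three numbers sit close together: the gaps separating compound 1 from compound 3 and from compound 2 both fall inside the usual scatter of repeated measurements, so compound 1 cannot be set apart from either of its companions on these data. At the single concentration tested, none of the three reduces the cell read-out by a large amount.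

Compound 4 `COc1cc(C)cc(-c2c(-c3ccnc(-c4ccc(N(C)C)cc4)c3)cnn2CC#N)c1` differs from compound 1 in one place: dimethylamino in place of acetyl on an aromatic carbon. The acetyl group leaves and a dimethylamino group enters, on an aromatic carbon of a six-membered aromatic ring of carbon only. Going by the values given here, no measured pair in this set shares that change, so nothing here shows how the assay responds to it. With the three measured compounds all lying within the scatter of one another despite differing elsewhere, no step beyond the scatter is expected in this assay. Compound 4 is therefore estimated at 80%, with a range from 65% to 95%, and the expected step of a number 1 percentage points lower from compound 1 to compound 4 (within the scatter) is small.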

Compound 4, a percentage reported as activity, at one concentration (the size of the read-out at that concentration, not a potency): 9%
The estimate for compound 4 lay 71 percentage points above the measured number; measured number below the stated range.
By their numbers in this assay, from the lowest: compound 4; then compounds 3, 1 and 2 (each within the scatter of the next).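

In this assay, the change from 4-acetylphenyl to 4-(dimethylamino)phenyl gives a number 72 percentage points lower from compound 1 to compound 4 (beyond the scatter). The earlier compounds shown here included no pair differing in one place, so they could not show that this position, on a six-membered aromatic ring of carbon only and para to a large group, strongly affects the read-out when a single group is exchanged. The two groups have the same counts of heavy atoms, hydrogen-bond donors and acceptors, and the same net charge, so those counts do not separate them, and nothing measured here explains the large step.

On these data alone, this is a single exchange at a single concentration, so it remains open whether the step is specific to dimethylamino or would also appear with another group here, such as a primary amine, a morpholine ring or a carboxylic acid. As far as these compounds go, it is also open whether the same exchange would have a similar effect on compound 2, which carries its acetyl group on a differently arranged framework.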